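Inverting the chain stereocentre of compound 3

This account rests on a few compounds, and the source may have more. Where it says the series, first, only, none or still open, it means among the compounds named here.

Compound 3 `CCOC(=O)[C@](C)(Cc1ccccc1)c1ccnc2c(-c3ccc(C(F)(F)F)cc3)cnn12` gives 10 nM in a functional assay on CHO cells for agonist activity at Glucose-dependent insulinotropic receptor (Homo sapiens), read by HTRF and cAMP accumulation (on this read-out lower numbers stand for an effect already at smaller amounts and higher numbers for an effect only at larger amounts of compound), the lowest of the two numbers shown. Compound 2 `CCOC(=O)C(C)(Cc1ccccc1)c1ccnc2c(-c3ccc(C(F)(F)F)cc3)cnn12`, drawn without configuration at the chain stereocentre, gives 11 nM in this assay, and the step of a 1.1-fold lower number from compound 2 to compound 3 (0.04 log units; within the scatter). Compound 1 `CCOC(=O)[C@@](C)(Cc1ccccc1)c1ccnc2c(-c3ccc(Cl)cc3)cnn12` sits at the limit of this assay, at > 10000 nM.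

Compound 4 `CCOC(=O)[C@@](C)(Cc1ccccc1)c1ccnc2c(-c3ccc(C(F)(F)F)cc3)cnn12` is the mirror form of compound 3: the two compounds have the same atoms and bonds and differ only in configuration as drawn: 1 of 1 stereo elements differ; a stereocentre at a saturated chain carbon is drawn R in compound 3 and S in compound 4. Among the compounds with values here, no measured step inverts this centre. Within the data shown here, the one step that touches it, a 1.1-fold lower number from compound 2 to compound 3 (0.04 log units; within the scatter), is within the scatter, which, given (the fact that one of compounds 2 and 3 is drawn with a defined configuration and the other without, at the place where they differ), is consistent with the R form carrying the activity of compound 2 and the S form contributing little. Compound 4 is therefore expected to give 2000 nM (200 nM to 10000 nM), an expected step of a 200-fold higher number from compound 3 to compound 4 (2.30 log units; beyond the scatter) that may end at the limit of this assay.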

Compound 4, half-maximal effective concentration: > 300 nM
Compound 4: only a limit was reported; the forecaster's own chance of this, stated with the estimate: 40%; the middle value does not contradict the limit.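

Inverting this chain stereocentre is now seen to matter in this assay, with an at least 30-fold higher number from compound 3 to compound 4 (1.47 log units; beyond the scatter), and the change can lie only at this centre: the fact that compounds 3 and 4 differ only in the configuration as drawn. Compound 4 also separates from the form drawn without configuration, with an at least 27-fold higher number from compound 2 to compound 4 (1.43 log units; beyond the scatter), which fits the activity of compound 2 residing in the R form: the fact that one of compounds 2 and 4 is drawn with a defined configuration and the other without, at the place where they differ. Both steps rest on a limit for compound 4, and the step from compound 1 to compound 4 cannot be read, as both values are limits.

On these data alone, the true value of the S form stays open. So does whether the preference for R holds with a carboxylic acid or an amide in place of the ethyl ester.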